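The compounds below may be only part of what the source reports. "The series", "measured", "known", "first", "only" and "open" are said of these compounds alone.

Three compounds already have numbers: compound 1 `Cn1cc(S(=O)(=O)N2CC(CNC(=O)c3ccc(Cl)cc3Cl)(c3ncccc3F)C2)cn1`, compound 2 `Cn1nncc1S(=O)(=O)N1CC(CNC(=O)c2ccc(Cl)cc2Cl)(CC2CC2)C1` and compound 3 `Cn1cc(S(=O)(=O)N2CCC(CNC(=O)c3ccc(Cl)cc3Cl)(CC3CC3)CC2)nn1`. In an assay on JAR cells for inhibition of sodium- and chloride-dependent glycine transporter 1 (Homo sapiens), read by scintillation counting, with a stated time of 3 h (a lower number here means a stronger inhibitor, a higher number a weaker inhibitor), compound 1 gives 2.95 nM, compound 2 gives 185 nM, and compound 3 gives 32 nM. Among these three numbers compound 3 stands second highest; its gap to compound 2 and its larger gap to compound 1 both lie beyond the scatter. Compound 4 `Cn1ncnc1S(=O)(=O)N1CCC(CNC(=O)c2ccc(Cl)cc2Cl)(CC2CC2)CC1` is the next candidate; it differs from compound 3 by 1-methyl-1H-1,2,4-triazol-5-yl in place of 1-methyl-1H-1,2,3-triazol-4-yl on a sulfonyl sulfur. Going by the values given here, no measured pair shows this change on its own, so the direction of the step is open. A modest step is expected, by a 1.4-fold higher number from compound 3 to compound 4 (0.15 log units; within the scatter), possibly none beyond the scatter. For compound 4 in this assay the estimate is 45 nM, within 15 nM to 150 nM.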

Compound 4, half-maximal inhibitory concentration: 314 nM
Estimate against measurement, compound 4: 7.0-fold (0.84 log units) below, outside the stated range (above it).
By their numbers in this assay, from the lowest: compound 1; then compound 3; then compounds 2 and 4 (each within the scatter of the next).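

In this assay, exchanging one triazole for the other on a sulfonyl sulfur gives a 9.8-fold higher number from compound 3 to compound 4 (0.99 log units; beyond the scatter), although the two groups have the same atoms and the same counts of hydrogen-bond donors and acceptors. At this position, then, how those atoms are arranged in the ring matters, and not only which atoms are present. Nothing available here accounts for the step. Still open, going by these compounds, is whether this exchange has a similar effect on the core of compound 1, and how a plain phenyl or an imidazole on the sulfonyl sulfur would compare.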